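The compounds below may be only part of what the source reports. "The series", "measured", "known", "first", "only" and "open" are said of these compounds alone.

The compounds measured so far:

compound 1, `N#Cc1ccc(-c2cnc3[nH]cc(-c4nnc(-c5ccc(F)cc5)o4)c(=O)c3c2)cc1` — 25.6%
compound 2, `CS(=O)(=O)c1ccc(-c2cnc3[nH]cc(-c4nnc(-c5ccncc5)o4)c(=O)c3c2)cc1` — 29.2%
compound 3, `CS(=O)(=O)c1ccc(-c2cnc3[nH]cc(-c4nnc(-c5ccccc5)o4)c(=O)c3c2)cc1` — 27.2%

In a functional assay on HCT-116 cells (Homo sapiens) for positive allosteric modulation, read by MTT assay, with stated times of 24 h and 48 h, tested at 2.5 uM (on this read-out lower numbers stand for less inhibition of growth and higher numbers for more inhibition of growth at the one concentration tested), the three numbers lie close together. Compound 3 sits between the other two: the step of a number 2 percentage points lower from compound 2 to compound 3 (within the scatter) is within the scatter, and the number of compound 1 differs from that of compound 3 by a similarly small margin, so none of the three can be set apart from the others.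

Compound 4, `Cc1ccc(-c2nnc(-c3c[nH]c4ncc(-c5ccc(S(C)(=O)=O)cc5)cc4c3=O)o2)cc1`, differs from compound 3 in one place: methyl in place of hydrogen on an aromatic carbon. Going by the values given here, the only measured step that touches the same ring is the one from compound 2 to compound 3, where a phenyl replaced a pyridin-4-yl and the number moved by an amount within the scatter. Among the compounds with values here, no measured pair shows the effect of adding a methyl, so there is no basis for expecting a shift in either direction beyond the scatter.

On this basis the expected step in this assay, a number 0.2 percentage points lower from compound 3 to compound 4 (within the scatter), is essentially flat. Compound 4 is therefore estimated at 27%, with a range from 17% to 37%.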

Compound 4, percent growth inhibition at one concentration: 54.8%
Compound 4: middle estimate off by 27.8 percentage points, on the low side; measured number outside the range, above it.
By their numbers in this assay, from the lowest: compounds 1, 3 and 2 (each within the scatter of the next); then compound 4.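

In this assay, going by these compounds alone, the change from phenyl to 4-methylphenyl, with the methyl para to a large group on a six-membered aromatic ring of carbon only, gives a number 27.6 percentage points higher from compound 3 to compound 4 (beyond the scatter), which shows that this position responds to a single added carbon in a way the earlier compounds could not reveal. Replacing pyridin-4-yl with 4-methylphenyl gives a number 25.6 percentage points higher from compound 2 to compound 4 (beyond the scatter), whereas phenyl in the same place gives a number 2 percentage points lower from compound 2 to compound 3 (within the scatter), so among these compounds the large step appears only when the methyl is present. Nothing measured here accounts for why so small an addition is followed by a step of this size.

As far as these compounds go, whether the step belongs to methyl alone or would also appear with an ethyl, a methoxy or a chlorine at the same place remains open. Also open, from the compounds shown here alone, is whether the methyl would have a similar effect with the nitrile of compound 1 in place of the methylsulfonyl group, and how the step would look across a range of concentrations rather than the single one used in this assay.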